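Working notes: bromo in place of iodo on compound 2

The source may hold more compounds than are shown below. What is called first, only, known or untested is meant among the compounds shown, and "the series" means these compounds.

Measured so far in an ADME assay on Huh-7 cells (Homo sapiens) for cytotoxicity; a lower number here means that less compound is tolerated, a higher number that more compound is tolerated (each entry is a limit and not a number):
compound 1 `COc1ccc(O[C@H]2C=C[C@@H](c3ccccc3)O[C@@H]2CO/N=C(\C)CCN2CCc3nc(-c4ccccc4)c(-c4ccccc4)cc3C2)cc1` gives > 50000 nM as a limit
compound 2 `O=C1C2C=C(I)C(CC2c2ccccc2)[C@]12CO2` gives > 50000 nM as a limit
compound 3 `O=C1C2C=C(I)C(CC2OCCCCO)[C@]12CO2` gives > 50000 nM as a limit

All three entries sit together, as the limit of > 50000 nM in this assay, at which 3 of the 3 values shown sit, shows. Compound 2 has > 50000 nM as its entry, which is a limit, so its place is known only as that limit.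

Compound 4 `O=C1C2C=C(Br)C(CC2c2ccccc2)[C@]12CO2` is not yet measured. It differs from compound 2 by one change (bromo in place of iodo on a double-bonded ring carbon), bromo in place of iodo on a double-bonded ring carbon.

Among the measured compounds shown here, the one measured step from compound 2 is a step that the two limits leave unreadable from compound 2 to compound 3 and it is a different change, 4-hydroxybutoxy in place of phenyl on a saturated ring carbon. For the measured compounds named here, no measured step exchanges iodo for bromo, so no size can be carried over to this change. Compound 2 with > 50000 nM as a limit is the only anchor for the expectation, so no step beyond the scatter is expected in this assay and no direction is favoured. The estimated step is a number no higher from compound 2 to compound 4 (the limit leaves the size open) in size. Compound 4 is expected near 50000 nM with an estimated range from 25000 nM to 100000 nM and is likely to be reported as a limit again.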

Compound 4, half-maximal cytotoxic concentration: > 50000 nM
Compound 4 gave a limit, no number; the forecaster's own chance of this, stated with the estimate: 80%; the middle value lies on the limit itself.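

Compound 2 and compound 4 are both entered only as limits in this assay, so no step can be read between them: the limit of > 50000 nM in this assay, at which 4 of the 4 values shown sit.

The compounds shown leave open whether bromo in place of iodo on a double-bonded ring carbon changes the half-maximal cytotoxic concentration at all, and where any of the four compounds would fall as a number.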